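The source may report more compounds than this note shows. Statements on the series, on what has been measured and on what is new or still open speak of the compounds shown alone.

Compound 1 `O=C(CSc1nc2ccccc2[nH]1)c1ccc(O)cc1` was examined in a functional assay on HT-29 cells (Homo sapiens) for inhibition, read by flow cytometry, tested at 10 uM (on this read-out lower numbers stand for less inhibition and higher numbers for more inhibition at the one concentration tested (going by the name of the read-out)), and gave "not active" (no number reported), so no single number marks where it stands; all that is known is that the read-out found no inhibition at the concentration tested. Two related compounds carry numbers: compound 2 `COc1ccc(C(=O)CSc2nc3ccccc3[nH]2)cc1OC` gives 52.6% in this assay, and compound 3 `COc1ccc(C(=O)CSc2nc3ccccc3[nH]2)cc1O` gives 49.7% in this assay. Among the measured compounds shown here, the one step recorded between measured compounds is a number 2.9 percentage points lower from compound 2 to compound 3 (within the scatter), a change of hydrogen in place of methyl on an oxygen on an aromatic ring. That step does not touch the kind of change now at issue, and it stays within the scatter, so it offers no guide to size or direction here.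

Compound 4 `Cc1ccc(C(=O)CSc2nc3ccccc3[nH]2)cc1` differs from compound 1 by methyl in place of hydroxy on an aromatic carbon. For the measured compounds named here, no measured step sets a hydroxy against a methyl at this place, so the expectation rests on compound 1 alone, which shows nothing measurable, while compounds 2 and 3 show that a substituted ring of this kind can reach about half inhibition. Compound 4 is therefore expected to fall in this assay near 20%, within a range from 0% to 50%, with a real chance that it too is simply reported as not active.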

Compound 4, a percentage reported as inhibition, at one concentration (the size of the read-out at that concentration, not a potency): 40%
Estimate against measurement, compound 4: 20 percentage points below; low and high end bracket the measured number.
By their numbers in this assay, from the lowest: compounds 4, 3 and 2 (each within the scatter of the next, the first and the last beyond it).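

In this assay compound 1 gives "not active" (no number reported) and compound 4 gives 40% as a number, so no step can be read between compound 1 and compound 4. The compounds shown leave open how large the effect of methyl in place of hydroxy is at this place. No measurement shown here bears on the cause of this result.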